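Benzyl in place of phenyl on compound 1

A few compounds are considered here, and "the series" means these few. Any claim that something is new, unique, unknown or untested is made for them only; others in the source may bear on it.

In a functional assay on the whole organism with Mus musculus as the target (a lower number here means that less compound is needed, a higher number that more compound is needed for the effect), compound 1 (`C[C@@H](NCc1ccc(OCc2ccccc2)cc1)C(N)=O`) gives 23.8 mg/kg and compound 2 (`CNC(=O)[C@@H](C)NCc1ccc(OCc2ccccc2)cc1`) gives 40.5 mg/kg. These two values lie within the scatter of each other, so neither compound can be ranked above the other.

Compound 3 (`C[C@@H](NCc1ccc(OCCc2ccccc2)cc1)C(N)=O`) has not yet been measured. Its difference from compound 1 is benzyl in place of phenyl on a saturated chain carbon bound to an oxygen on an aromatic ring. Among the compounds with values here, no measured step covers that place. Within the data shown here, the only measured step, a 1.7-fold higher number from compound 1 to compound 2 (0.23 log units; within the scatter), is methyl in place of hydrogen on an amide-type nitrogen, so it is a weak guide and the range must stay wide.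

The expected step is a 1.3-fold higher number from compound 1 to compound 3 (0.10 log units; within the scatter), with nothing beyond the scatter anticipated in this assay. For compound 3 the estimate is 30 mg/kg, with an expected range of 12 mg/kg to 80 mg/kg.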

Compound 3, dose for half-maximal effect: 24.9 mg/kg
Compound 3: the middle estimate sits 1.2-fold (0.08 log units) above what was measured, and the stated range covers the measured number.
By their numbers in this assay, from the lowest: compounds 1, 3 and 2 (each within the scatter of the next).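

Going from phenyl to benzyl on a saturated chain carbon bound to an oxygen on an aromatic ring gives, in this assay, a 1.0-fold higher number from compound 1 to compound 3 (0.02 log units; within the scatter) and is the first measured step at this place. The earlier pair differed only on the amide-type nitrogen, so it could not show that this exchange leaves compound 1 and compound 3 indistinguishable in this read-out. No measurement bears on a cause for this result.

Open, on these data alone, is whether a longer chain carrying the phenyl ring, or an amine or a carboxylic acid at this place, would stay within the scatter of compound 1. Also open, as far as these compounds go, is whether methyl on the amide-type nitrogen, seen in a 1.7-fold higher number from compound 1 to compound 2 (0.23 log units; within the scatter) on the shared core, would give a similar step on compound 3.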